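Swapping Nitro for Chloro on a Shared Triazole Acetamide Core

The compounds below may be only part of what the source reports. "The series", "measured", "known", "first", "only" and "open" are said of these compounds alone.

Three compounds built on one shared core were tested in a functional assay on BMDM cells (Mus musculus, strain C57BL/6) for inhibition, with a stated time of 2 days; on this read-out higher numbers stand for weaker inhibition and lower numbers for stronger inhibition. Compound 1 `O=C(Cn1cc(-c2ccc([N+](=O)[O-])cc2)nn1)Nc1nccs1` gives 1040 nM. Compound 2 `O=C(Cn1cc(-c2ccc([N+](=O)[O-])cc2)nn1)Nc1nc2ccccc2s1` gives 3280 nM, and compound 3 `Cc1cc(NC(=O)Cn2cc(-c3ccc([N+](=O)[O-])cc3)nn2)no1` gives 1220 nM. Compound 1 has the lowest number of the three: its step to compound 3 stays within the scatter, a 1.2-fold higher number from compound 1 to compound 3 (0.07 log units; within the scatter), while its step to compound 2 lies beyond it, a 3.2-fold higher number from compound 1 to compound 2 (0.50 log units; beyond the scatter). Between the other two the step is a 2.7-fold lower number from compound 2 to compound 3 (0.43 log units; beyond the scatter). All three measured steps alter only the group on the amide-type nitrogen; the nitro-bearing ring is the same in every one.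

Compound 4 `O=C(Cn1cc(-c2ccc(Cl)cc2)nn1)Nc1nccs1` differs from compound 1 at a different place: chloro in place of nitro on an aromatic carbon. Going by the values given here, no measured step touches this ring, so none of the three steps bears directly on the change; they show only that alterations elsewhere on the core have stayed modest. Without a direct guide, a modest step in either direction, or none beyond the scatter, is expected in this assay for compound 4, whose estimate is 1500 nM with a range from 400 nM to 6000 nM. The step this estimate implies for compound 4 is expected to be a 1.4-fold higher number from compound 1 to compound 4 (0.16 log units; within the scatter).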

Compound 4, half-maximal inhibitory concentration: 1100 nM
Compound 4: middle estimate off by 1.4-fold (0.13 log units), on the high side, within the range that was stated.
By their numbers in this assay, from the lowest: compounds 1, 4 and 3 (each within the scatter of the next); then compound 2.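

In this assay, going by these compounds alone, the step for chloro in place of nitro on this aromatic carbon is a 1.1-fold higher number from compound 1 to compound 4 (0.02 log units; within the scatter), giving the first direct reading at a position that none of the earlier steps touched. The exchange is a large one in simple counts: nitro brings 3 heavy atoms, 2 hydrogen-bond acceptors and a double bond, whereas chloro is a single heavy atom with no hydrogen-bond acceptors, yet the two compounds cannot be told apart on this read-out, so the features that nitro alone carries are not needed to reach a number of this size. The data offer no measurement that explains why these two groups read alike.

As far as these compounds go, it remains open how far this tolerance extends, since an amine, a methoxy group or a carboxylic acid on the same carbon, with the rest of compound 1 unchanged, could give a different answer. From the compounds shown here alone, it is also open whether chloro and nitro would still read alike with the 1,3-benzothiazol-2-yl group of compound 2 or the 5-methyl-1,2-oxazol-3-yl group of compound 3 on the amide-type nitrogen.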